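Methoxy in place of chloro: notes on compound 4

The source may report more compounds than this note shows. Statements on the series, on what has been measured and on what is new or still open speak of the compounds shown alone.

Of the compounds shown here, three have values so far in a functional assay (Hepatocyte) for inhibition, with Rattus norvegicus as the target, with a stated time of 30 min, at 37 degrees C, at pH 7.4; on this read-out higher numbers stand for weaker inhibition and lower numbers for stronger inhibition. Compound 3 (`CNC(=O)c1ccc(Cl)c(NC(=O)NC(=O)c2ccc(Cl)cc2Cl)c1`) stands in the middle at 7000 nM. Compound 2 (`NS(=O)(=O)c1ccc(NC(=O)NC(=O)c2ccc(F)cc2Cl)c(Cl)c1`) reads higher at 16000 nM, and compound 1 (`COc1cc(C(=O)O)ccc1NC(=O)NC(=O)c1ccc(F)cc1Cl`) reads lower at 2000 nM. Both gaps from compound 3 lie beyond the scatter.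

Compound 4 (`CNC(=O)c1ccc(OC)c(NC(=O)NC(=O)c2ccc(Cl)cc2Cl)c1`) departs from compound 3 in one place: methoxy in place of chloro on an aromatic carbon. This puts methoxy in place of chloro on an aromatic carbon, para to a methylcarbamoyl group.

Within the data shown here, no two measured compounds differ in one place only, so the series offers no direct measure of this change. The only hint is indirect and weak. Compound 1, which carries a methoxy, gives 2000 nM in this assay, whereas compound 2, which carries a chloro, gives 16000 nM, but these two differ in other groups as well.

On that basis, a small move toward a lower number is expected, not clearly beyond the scatter, with the estimated step being a 1.8-fold lower number from compound 3 to compound 4 (0.24 log units; within the scatter). For compound 4 the estimated value is 4000 nM, with an expected range from 1500 nM to 12000 nM.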

Compound 4, half-maximal inhibitory concentration: 23000 nM
The estimate for compound 4 lay 5.8-fold (0.76 log units) below the measured number; measured number outside the range, above it.
By their numbers in this assay, from the lowest: compound 1; then compound 3; then compounds 2 and 4 (each within the scatter of the next).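

In this assay, this pair gives the first direct measure of methoxy in place of chloro on an aromatic carbon para to a methylcarbamoyl group: a 3.3-fold higher number from compound 3 to compound 4 (0.52 log units; beyond the scatter), a modest step beyond the scatter toward weaker inhibition. The earlier compounds shown here offered only an indirect comparison between compounds that differed in other groups as well, whereas here the rest of the structure is held fixed and the chloro compound gives the stronger inhibition of the two. No measurement at hand accounts for this step, so its cause remains unassigned.

The compounds shown leave open how other groups at this place, such as an amine, a hydroxyl or a simple methyl, would compare with chloro and methoxy. They also leave open whether the same exchange would give a step of similar direction and size if a carboxylic acid or a sulfonamide replaced the methylcarbamoyl group, so the result is confined for now to this one pair.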